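This account rests on a few compounds, and the source may have more. Where it says the series, first, only, none or still open, it means among the compounds named here.

Measured compounds:
Compound 1 `FC(F)(F)c1ccc(CN2CCN(Cc3cc(-c4ccc(OCc5ccccc5)cc4)on3)CC2)cc1` gives 2900 nM in a functional assay on MCF7 cells (Homo sapiens) for antiproliferative activity, read by sulforhodamine B assay, with a stated time of 72 h; on this read-out lower numbers stand for stronger inhibition and higher numbers for weaker inhibition.
Compound 2 `Cc1cccc(COc2ccc(-c3cc(CN4CCN(Cc5ccc(C(F)(F)F)cc5)CC4)no3)cc2)c1` gives 4000 nM in this assay.
Compound 3 `Cc1ccc(COc2ccc(-c3cc(CN4CCN(Cc5ccc(C(F)(F)F)cc5)CC4)no3)cc2)cc1` gives 1200 nM in this assay.

Compound 1 holds the second highest of the three numbers. Its nearest neighbour is compound 2, with a 1.4-fold higher number from compound 1 to compound 2 (0.14 log units; within the scatter), and its furthest is compound 3, with a 2.4-fold lower number from compound 1 to compound 3 (0.38 log units; beyond the scatter). The two methyl analogues also differ from each other, with a 3.3-fold lower number from compound 2 to compound 3 (0.52 log units; beyond the scatter).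

Compound 4 `FC(F)(F)c1ccc(CN2CCN(Cc3cc(-c4ccc(OCc5ccccc5Cl)cc4)on3)CC2)cc1` differs from compound 1 by chloro in place of hydrogen on an aromatic carbon. Within the data shown here, the steps that bear on this change are the two methyl substitutions on the same benzyl ring of compound 1: a 1.4-fold higher number from compound 1 to compound 2 (0.14 log units; within the scatter), within the scatter, and a 2.4-fold lower number from compound 1 to compound 3 (0.38 log units; beyond the scatter), a modest lowering. Neither of them tests chloro, and neither places its group ortho to a large group, so the bearing is indirect. Substitution on this ring has so far produced at most a modest change in this assay, and a step in either direction beyond the scatter is therefore not expected for compound 4.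

Compound 4 is accordingly expected to give about 2500 nM in this assay, within a range of 900 nM to 7000 nM. This estimate corresponds to a step of a 1.2-fold lower number from compound 1 to compound 4 (0.06 log units; within the scatter) and is expected to fall within the scatter.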

Compound 4, half-maximal inhibitory concentration: 2800 nM
The estimate for compound 4 lay 1.1-fold (0.05 log units) below the measured number, within the range that was stated.
By their numbers in this assay, from the lowest: compound 3; then compounds 4, 1 and 2 (each within the scatter of the next).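

In this assay, among these compounds, chloro in place of hydrogen on an aromatic carbon, ortho to a large group, produces no change beyond the scatter, with a 1.0-fold lower number from compound 1 to compound 4 (0.02 log units; within the scatter); this is the first look at a group in this place on the benzyl ring, and here a hydrogen and a chloro cannot be told apart. Among the compounds shown here, compound 4 also stays within the scatter of the 3-methylphenyl analogue, with a 1.4-fold lower number from compound 2 to compound 4 (0.15 log units; within the scatter), whereas a 2.3-fold higher number from compound 3 to compound 4 (0.37 log units; beyond the scatter) is a modest step beyond the scatter, so compound 3, with its 4-methylphenyl group, remains the only one of the four compounds set apart from the others, with the lowest number. No measurement is available that would account for these numbers.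

On these data alone, what a chloro would give at the ring place that carries the methyl in compound 3 remains open, so the modest step seen there cannot yet be assigned to that place or to the methyl itself. Also open, as far as these compounds go, is whether a methoxy group, an amine or a carboxylic acid on the same ortho carbon would stay as close to compound 1 as chloro does.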